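A few compounds are considered here, and "the series" means these few. Any claim that something is new, unique, unknown or untested is made for them only; others in the source may bear on it.

Among the measured compounds shown here, in a functional assay on NTUB1 cells (Homo sapiens) for cytotoxicity, read by MTT assay, with a stated time of 72 h (a higher number here means a weaker inhibitor, a lower number a stronger inhibitor), compound 2 `COc1ccc(OC)c(C(=O)/C=C/c2ccc(C(=O)OCC=C(C)C)cc2)c1` gives 13400 nM, the highest of the three numbers so far. Compound 1 `COc1ccc(OC)c(C(=O)/C=C/c2ccc(C(=O)OC(C)C)cc2)c1` gives 4420 nM, and compound 3 `CCNC(=O)c1ccc(/C=C/C(=O)c2cc(OC)ccc2OC)cc1` gives 3760 nM. Compound 4 `CCN(CC)C(=O)c1ccc(/C=C/C(=O)c2cc(OC)ccc2OC)cc1` is still unmeasured and differs from compound 2 by diethylamino in place of (3-methylbut-2-en-1-yl)oxy on a carbonyl carbon. The closest evidence is a 3.6-fold lower number from compound 2 to compound 3 (0.55 log units; beyond the scatter), where ethylamino enters on that carbonyl carbon. Two further steps frame it: a 3.0-fold higher number from compound 1 to compound 2 (0.48 log units; beyond the scatter) and a 1.2-fold lower number from compound 1 to compound 3 (0.07 log units; within the scatter). For the measured compounds named here, no measured compound carries diethylamino, so a modest step to a lower number in this assay is only an expectation. The expected change is a 2.7-fold lower number from compound 2 to compound 4 (0.43 log units; beyond the scatter). Compound 4 is estimated at 5000 nM, with a range of 2000 nM to 12000 nM.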

Compound 4, half-maximal inhibitory concentration: 2690 nM
Compound 4: middle estimate off by 1.9-fold (0.27 log units), on the high side; the measured number falls inside the stated range.
By their numbers in this assay, from the lowest: compounds 4, 3 and 1 (each within the scatter of the next); then compound 2.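

In this assay, a second nitrogen group on this carbonyl carbon also gives a lower number than the (3-methylbut-2-en-1-yl)oxy ester: a 5.0-fold lower number from compound 2 to compound 4 (0.70 log units; beyond the scatter). Putting an ethyl in place of the hydrogen on the amide-type nitrogen stays within the scatter, with a 1.4-fold lower number from compound 3 to compound 4 (0.15 log units; within the scatter), and so does the change from isopropoxy, with a 1.6-fold lower number from compound 1 to compound 4 (0.22 log units; within the scatter). Compound 2 thus stands apart from the other three compounds, and nothing measured here explains why. Still open, as far as these compounds go, is where a piperidine amide or a free carboxylic acid at this carbonyl carbon would fall, whether with those three or with compound 2.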